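Sugar-linked series: cytotoxicity notes toward compound 4

The source may hold more compounds than are shown below. What is called first, only, known or untested is meant among the compounds shown, and "the series" means these compounds.

Measured so far:
compound 1, `CC(=O)C[C@H]1O[C@@H](On2cc(CN3C(=O)C(=O)c4ccccc43)nn2)[C@H](OC(C)=O)[C@@H](OC(C)=O)[C@@H]1OC(C)=O`, 137000 nM
compound 2, `CC1(C)O[C@H]2O[C@H](Cn3cc(CN4C(=O)C(=O)c5ccccc54)nn3)[C@H](O)[C@H]2O1`, > 200000 nM
compound 3, `COc1ccc(N/N=C2\C(=O)N(Cc3cn(O[C@@H]4O[C@H](CC(C)=O)[C@@H](OC(C)=O)[C@H](OC(C)=O)[C@H]4OC(C)=O)nn3)c3ccccc32)cc1`, 95300 nM

In an ADME assay on Vero cells (Chlorocebus sabaeus) for cytotoxicity, read by fluorescence and resazurin assay, with a stated time of 3 days (a lower number here means that less compound is tolerated, a higher number that more compound is tolerated), compound 3 holds the lower of the two numbers, though the gap to compound 1 lies within the scatter. For compound 2 the value in this assay is a limit of the assay, not a number, as recorded in the limit of > 200000 nM in this assay, at which 1 of the 3 values shown sits. Compound 4, `CC(=O)C[C@H]1O[C@@H](On2cc(CN3C(=O)/C(=N\Nc4cccc(Cl)c4)c4ccccc43)nn2)[C@H](OC(C)=O)[C@@H](OC(C)=O)[C@@H]1OC(C)=O`, is not yet measured and differs from compound 3 in one place: 3-chlorophenyl in place of 4-methoxyphenyl on an amine nitrogen. Within the data shown here, no step between measured compounds isolates a change of this kind, so no measured size can be drawn on. Since the gap between compound 3 and compound 1 lies within the scatter, for compound 4 in this assay a step no larger than the scatter is expected, a 1.1-fold lower number from compound 3 to compound 4 (0.05 log units; within the scatter). Compound 4 is estimated at 85000 nM, between 35000 nM and 190000 nM.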

Compound 4, half-maximal cytotoxic concentration: 117000 nM
Estimate against measurement, compound 4: 1.4-fold (0.14 log units) below; low and high end bracket the measured number.
By their numbers in this assay, from the lowest: compounds 3, 4 and 1 (each within the scatter of the next). At a limit, above all of these: compound 2.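

Placing 3-chlorophenyl in place of 4-methoxyphenyl on this amine nitrogen gives a 1.2-fold higher number from compound 3 to compound 4 (0.09 log units; within the scatter) in this assay and does not tell the two groups apart. Among these compounds, the earlier compounds offered no step at this place, so this is the first reading of a change here. Nothing measured in the series accounts for the size of this step.

Among the compounds shown here, this single pair covers only two substituted phenyl groups. From the compounds shown here alone, whether a carboxylic acid or an amine carried on the phenyl ring would also stay within the scatter in this assay remains open.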